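The source may hold more compounds than are shown below. What is called first, only, known or untested is meant among the compounds shown, and "the series" means these compounds.

Measured so far:
- Compound 1, `COc1cc2cc(Oc3ccc(NC(=O)Nc4cccc(C(F)(F)F)c4)cc3)c(C)nc2cc1OC`: in a functional assay on Hs-578T cells (Homo sapiens) for inhibition, read by sulforhodamine B assay, with a stated time of 48 h (a higher number here means a weaker inhibitor of growth, a lower number a stronger inhibitor of growth), compound 1 gives 4220 nM.
- Compound 2, `COc1cc2cc(Oc3ccc(NC(=O)Nc4ccc(Cl)c(C(F)(F)F)c4)cc3)c(C)nc2cc1OC`: in this assay compound 2 gives 2310 nM.

Among the measured compounds shown here, compound 2 stands at the lower of the two numbers, but its only neighbour is compound 1, and the step of a 1.8-fold lower number from compound 1 to compound 2 (0.26 log units; within the scatter) lies within the scatter, so the two compounds cannot be told apart on these numbers.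

Compound 3, `COc1cc2cc(Oc3ccc(NC(=O)Nc4ccc(Cl)c(Cl)c4)cc3)c(C)nc2cc1OC`, has not yet been measured. It differs from compound 2 by chloro in place of trifluoromethyl on an aromatic carbon. For the measured compounds named here, no measured step bears directly on this change: the one step known, a 1.8-fold lower number from compound 1 to compound 2 (0.26 log units; within the scatter), concerns a chloro entering in place of hydrogen, not in place of trifluoromethyl, and that step itself did not rise above the scatter. With nothing pointing either way, the expectation for compound 3 in this assay is a step of a 1.2-fold higher number from compound 2 to compound 3 (0.08 log units; within the scatter), that is, no shift beyond the scatter. Compound 3 is therefore estimated at 2800 nM, with a range from 1100 nM to 7000 nM.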

Compound 3, concentration for total growth inhibition: 9680 nM
The estimate for compound 3 lay 3.5-fold (0.54 log units) below the measured number; the whole stated range lies below it.
By their numbers in this assay, from the lowest: compounds 2 and 1 (each within the scatter of the next); then compound 3.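

In this assay, among the compounds shown here, the position that carries trifluoromethyl in compound 2, on an aromatic carbon ortho to a chloro group, turns out to be sensitive to what sits there: the change to chloro gives a 4.2-fold higher number from compound 2 to compound 3 (0.62 log units; beyond the scatter) and is the only step so far, apart from the one described next, to pass beyond the scatter. The 3,4-dichlorophenyl group also stands apart from the 3-(trifluoromethyl)phenyl group, with a 2.3-fold higher number from compound 1 to compound 3 (0.36 log units; beyond the scatter) as the printed step, so compound 3 separates from compound 1 and compound 2, which remain within the scatter of each other. Nothing in the data shown bears on the reason for these steps.

What the compounds shown leave open is where other groups at this position, such as a methyl, a methoxy, a fluoro or a nitrile, would fall relative to compound 2 and compound 3. Also open, as far as these compounds go, is whether chloro in place of trifluoromethyl would give a step of similar size with hydrogen instead of the chloro group ortho to it, or on a different group at the far end of the molecule.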